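The source may hold more compounds than are shown below. What is called first, only, known or untested is meant among the compounds shown, and "the series" means these compounds.

Measured so far in an assay on cells for binding affinity to Myc proto-oncogene protein (Homo sapiens); a lower number here means a stronger inhibitor, a higher number a weaker inhibitor:
- compound 1 `N#Cc1ccc(-c2cc(-c3ccc(C(N)=O)cc3)cc(-c3ccco3)n2)cc1`: 3000 nM
- compound 2 `N#Cc1ccc(-c2cc(-c3ccc(C(N)=O)cc3)cc(-c3cnco3)n2)cc1`: > 100000 nM
- compound 3 `CNC(=O)c1ccc(-c2cc(-c3ccc(C#N)cc3)nc(-c3ccco3)c2)cc1`: "not determined" (no result reported)

Compound 3 `CNC(=O)c1ccc(-c2cc(-c3ccc(C#N)cc3)nc(-c3ccco3)c2)cc1` has no number in this assay; of the two values shown for the series, one is a plain number and one is a limit. For compound 2 the value > 100000 nM is a limit of this assay, not a number (the limit of > 100000 nM in this assay, at which 1 of the 3 values shown sits). Compound 1 gives 3000 nM in this assay.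

Within the data shown here, the only measured step, an at least 33-fold higher number from compound 1 to compound 2 (1.52 log units; beyond the scatter), exchanges the ring on the aromatic carbon and leaves the carboxamide untouched. It therefore says nothing about the change at the amide nitrogen.

Compound 4 `N#Cc1ccc(-c2cc(-c3ccc(C(=O)NN)cc3)cc(-c3ccco3)n2)cc1` differs from compound 3 by amino in place of methyl on an amide-type nitrogen. Compound 4 carries the same furan-2-yl ring and the same nitrile-bearing ring as compound 1; the remaining difference to compound 1 is confined to the amide nitrogen. Among the measured compounds shown here, no measured step covers such a change, so no step beyond the scatter is expected in either direction in this assay, and the value of compound 1, 3000 nM, is the reference.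

Compound 4 is expected to give about 3500 nM in this assay, with a range from 1000 nM to 15000 nM.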

Compound 4, half-maximal inhibitory concentration: > 100000 nM
Compound 4: a limit, no number; the forecaster's own chance of this, stated with the estimate: 15%; middle value at least 28-fold (1.45 log units) from the limit.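

In this assay, compound 4 gives > 100000 nM, a limit of the assay and not a number. With the furan-2-yl ring and the nitrile-bearing ring unchanged, amino in place of hydrogen on the amide-type nitrogen gives an at least 33-fold higher number from compound 1 to compound 4 (1.52 log units; beyond the scatter), so this nitrogen, which the earlier step left untouched, proves to be a position where a single added heavy atom can carry the series out of the measurable range. Single changes at two different places on the core of compound 1, the furan-2-yl ring and the amide nitrogen, now end at the same limit: the limit of > 100000 nM in this assay, at which 2 of the 4 values shown sit.

From the compounds shown here alone, compound 3 has no number in this assay, so the step between methyl and amino on the amide nitrogen cannot be read, and the effect of methyl at this position stays open. Also open, going by these compounds, is whether the result is specific to amino or extends to other groups on this nitrogen, such as hydroxy or ethyl, and whether any of them stays close to compound 1 at 3000 nM.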